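Amide aryl swap on a flavonol core: compound 4

The compounds below may be only part of what the source reports. "The series", "measured", "known", "first", "only" and "open" are said of these compounds alone.

Measured so far in a functional assay on MCF7 cells (Homo sapiens) for antiproliferative activity, read by CCK-8 assay, with a stated time of 72 h; a lower number here means a stronger inhibitor, a higher number a weaker inhibitor:
Compound 1, `O=C(Nc1cccc(-c2oc3cc(-c4ccc(F)cc4)ccc3c(=O)c2O)c1)c1ccc(F)cc1`, gives 8590 nM.
Compound 2, `Cc1ccc(C(=O)Nc2cccc(-c3oc4cc(-c5ccc(F)cc5)ccc4c(=O)c3O)c2)cc1`, gives 2400 nM.
Compound 3, `O=C(Nc1cccc(-c2oc3cc(-c4ccc(F)cc4)ccc3c(=O)c2O)c1)c1ccc(C(F)(F)F)cc1`, gives 32600 nM.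

Compound 3 holds the highest number of the three. Its nearest neighbour is compound 1, reached by a 3.8-fold higher number from compound 1 to compound 3 (0.58 log units; beyond the scatter); the gap to compound 2 is the widest, as seen in a 14-fold higher number from compound 2 to compound 3 (1.13 log units; beyond the scatter).

Compound 4, `Cc1cc(C(=O)Nc2cccc(-c3oc4cc(-c5ccc(F)cc5)ccc4c(=O)c3O)c2)ccc1F`, has not been measured. It differs from compound 3 in one place: 4-fluoro-3-methylphenyl in place of 4-(trifluoromethyl)phenyl on a carbonyl carbon. Both measured steps that end at compound 3 bear on this change, since each removes the trifluoromethyl group in favour of a single small substituent, fluoro in the step from compound 1 and methyl in the step from compound 2. Compound 4 carries both a fluoro and a methyl on the entering ring, so the expected step lies somewhere between those two, toward a lower number in this assay.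

Compound 4 is therefore expected to show a 6.5-fold lower number from compound 3 to compound 4 (0.81 log units; beyond the scatter), landing at an estimated 5000 nM with a range of 1500 nM to 15000 nM.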

Compound 4, half-maximal inhibitory concentration: 7710 nM
Estimate against measurement, compound 4: 1.5-fold (0.19 log units) below, and the stated range covers the measured number.
By their numbers in this assay, from the lowest: compound 2; then compounds 4 and 1 (each within the scatter of the next); then compound 3.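

In this assay, 4-fluoro-3-methylphenyl in place of 4-(trifluoromethyl)phenyl on the carbonyl carbon gives a 4.2-fold lower number from compound 3 to compound 4 (0.63 log units; beyond the scatter), so the weak reading of compound 3 does not carry over to this ring. Methyl in place of hydrogen on an aromatic carbon of the amide aryl ring of compound 1 gives a 1.1-fold lower number from compound 1 to compound 4 (0.05 log units; within the scatter), which leaves compound 4 level with compound 1 and not with compound 2. The 4-methylphenyl of compound 2 stays ahead, with a 3.2-fold higher number from compound 2 to compound 4 (0.51 log units; beyond the scatter), showing that a methyl on this ring does not by itself bring the lower number.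

Still open, as far as these compounds go, is whether a methoxy group or an amine on this ring would reach a lower number than compound 2 does. No measurement given here accounts for any of these steps.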